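The source may hold more compounds than are shown below. What is called first, only, known or untested is meant among the compounds shown, and "the series" means these compounds.

Compound 1 `COc1cc(-c2nn(-c3cccc(NC(=O)c4ccc(Cl)c(C(F)(F)F)c4)c3)cc2-c2ccncc2)ccc1Cl` gives only a limit in a functional assay on NCI-H322M cells (Homo sapiens) for inhibition, read by sulforhodamine B assay, with a stated time of 48 h; a higher number here means a weaker inhibitor of growth, a lower number a stronger inhibitor of growth: its value of > 32500 nM is a limit of the assay, not a number, and it is one of the limit of > 32500 nM in this assay, at which 2 of the 3 values shown sit. Compound 4 `COc1cc(-c2nn(-c3cccc(NC(=O)Nc4ccc(Cl)c(Cl)c4)c3)cc2-c2ccncc2)ccc1Cl` differs from it in one place: (3,4-dichlorophenyl)amino in place of 4-chloro-3-(trifluoromethyl)phenyl on a carbonyl carbon. Going by the values given here, no measured pair covers this exact change. The nearest guide comes from the urea compounds. Compound 2 `O=C(Nc1cccc(-n2cc(-c3ccncc3)c(-c3ccc(Cl)c(O)c3)n2)c1)Nc1cccc(C(F)(F)F)c1` gives in this assay a limit of > 32500 nM. Compound 3 `O=C(Nc1cccc(-n2cc(-c3ccncc3)c(-c3ccc(Cl)c(O)c3)n2)c1)Nc1ccc(Cl)c(C(F)(F)F)c1` gives 4480 nM, and between them lies an at least 7.2-fold lower number from compound 2 to compound 3 (0.86 log units; beyond the scatter). Since compound 4 carries the urea and a chloro as compound 3 does, a number below the limit is expected, an at least 4.0-fold lower number from compound 1 to compound 4 (0.60 log units; beyond the scatter). Compound 4 is therefore estimated at 8000 nM, with a range from 2000 nM to 32500 nM.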

Compound 4, concentration for total growth inhibition: > 50000 nM
Compound 4 was reported as a limit; the forecaster's own chance of this, stated with the estimate: 35%; at least 6.2-fold (0.79 log units) between middle value and limit.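

In this assay compound 1 gives > 32500 nM as a limit. Going by these compounds alone, compound 4 gives > 50000 nM as a limit too, so no step between compound 1 and compound 4 can be read. The compounds shown leave open whether (3,4-dichlorophenyl)amino in place of 4-chloro-3-(trifluoromethyl)phenyl changes growth inhibition at all.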